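Swapping an amide arm for a carbamoyl arm

The compounds below may be only part of what the source reports. "The series", "measured", "known", "first", "only" and "open" are said of these compounds alone.

Measured so far:
compound 1, `COc1cc(-c2nn(-c3cccc(NC(=O)Nc4cc(C(F)(F)F)cc(C(F)(F)F)c4)c3)cc2-c2ccncc2)ccc1Cl`, 858 nM
compound 2, `COc1cc(-c2nn(-c3cccc(NC(=O)c4cccc(C(F)(F)F)c4)c3)cc2-c2ccncc2)ccc1Cl`, 1130 nM

In a functional assay on SNB-75 cells (Homo sapiens) for inhibition, read by sulforhodamine B assay, with a stated time of 48 h (a lower number here means a stronger inhibitor of growth, a higher number a weaker inhibitor of growth), compound 2 gives the higher of the two numbers, but its nearest neighbour, compound 1, is within the scatter, so the two cannot be told apart.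

Compound 3, `COc1cc(-c2nn(-c3cccc(NC(=O)Nc4ccc(Cl)c(Cl)c4)c3)cc2-c2ccncc2)ccc1Cl`, has not yet been measured. It differs from compound 2 in one place: (3,4-dichlorophenyl)amino in place of 3-(trifluoromethyl)phenyl on a carbonyl carbon. Compound 1 carries a carbamoyl link of the same kind, and in this assay compound 1 gives 858 nM, a value within the scatter of compound 2. On that basis the step of a 1.3-fold lower number from compound 2 to compound 3 (0.10 log units; within the scatter) is expected to be small, if anything slightly downward, and not clearly beyond the scatter. Compound 3 is therefore estimated at 900 nM, with a plausible range from 400 nM to 2000 nM.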

Compound 3, concentration for 50% growth inhibition: 1050 nM
The estimate for compound 3 lay 1.2-fold (0.07 log units) below the measured number, and the stated range covers the measured number.
By their numbers in this assay, from the lowest: compounds 1, 3 and 2 (each within the scatter of the next).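

In this assay, changing (3-(trifluoromethyl)phenyl)carbonyl to (3,4-dichlorophenyl)carbamoyl gives a 1.1-fold lower number from compound 2 to compound 3 (0.03 log units; within the scatter), so this position tolerates a swap of the whole arm without a readable change in growth inhibition. The swap brings in an amide-type nitrogen with a hydrogen-bond donor and replaces trifluoromethyl with two chlorines, and since these changes come together, this step cannot separate what each does alone. No measurement is available to explain this result.

A plain phenyl on the same carbamoyl link would help separate the effect of the link from that of the chlorines. Going by these compounds, it also remains open whether a quite different end group on the carbonyl carbon, such as a piperidine ring or a benzoic acid, would move the number beyond the scatter.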